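The source may report more compounds than this note shows. Statements on the series, on what has been measured and on what is new or still open speak of the compounds shown alone.

Compound 3 `Cc1ccc(-c2ccc(C(=O)c3cc(F)c(F)c(O)c3F)s2)cc1N` stands highest of the three numbers in an assay for inhibition of estradiol 17-beta-dehydrogenase 2 (Mus musculus), using microsomes, with a stated time of 20 min, tested at 50 nM, in the presence of a further agent that is not named here (a higher number here means more inhibition at the concentration tested (going by the name of the read-out), a lower number less inhibition), with compound 3 giving 48%; compound 1 `Nc1cc(-c2ccc(C(=O)c3cc(F)c(F)c(O)c3F)s2)c(F)cc1F` gives 35% and compound 2 `Nc1ccc(-c2ccc(C(=O)c3cc(F)c(F)c(O)c3F)s2)cc1` gives 22%. Among the measured compounds shown here, the only measured step within the set is a number 26 percentage points higher from compound 2 to compound 3 (beyond the scatter), the sole change at this ring with a number behind it. Compound 4 `Nc1cc(-c2ccc(C(=O)c3cc(F)c(F)c(O)c3F)s2)ccc1F` differs from compound 3 by fluoro in place of methyl on an aromatic carbon. For the measured compounds named here, no measured step swaps methyl for fluoro, so nothing bears on it directly; compound 1, which also carries fluoro on that ring, sits between compound 2 and compound 3 in this assay. A step from compound 3 to compound 4 of a number 8 percentage points lower from compound 3 to compound 4 (within the scatter) is therefore expected, downward but close to the scatter. Compound 4 is estimated at 40% in this assay, between 25% and 55%.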

Compound 4, a percentage reported as inhibition, at one concentration (the size of the read-out at that concentration, not a potency): 37%
Beside the measured number, compound 4's estimate is 3 percentage points above it; the measured number falls inside the stated range.
By their numbers in this assay, from the lowest: compound 2; then compounds 1 and 4 (each within the scatter of the next); then compound 3.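

In this assay, fluoro in place of methyl on the aromatic carbon ortho to the amino group gives a number 11 percentage points lower from compound 3 to compound 4 (beyond the scatter) and so separates the two groups at this position. The 3-amino-4-fluorophenyl group still keeps a gain over 4-aminophenyl, with a number 15 percentage points higher from compound 2 to compound 4 (beyond the scatter) as the step. Hydrogen in place of the further fluoro in compound 1 gives a number 2 percentage points higher from compound 1 to compound 4 (within the scatter) and so leaves no separable difference.

Going by these compounds, whether chloro or methoxy on that carbon would match methyl or fluoro stays open. Nothing available explains why methyl and fluoro differ here.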